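A few compounds are considered here, and "the series" means these few. Any claim that something is new, unique, unknown or untested is made for them only; others in the source may bear on it.

Among the measured compounds shown here, in an ADME assay on Vero 76 cells (Chlorocebus sabaeus) for cytotoxicity, read by crystal violet staining, with a stated time of 96 h (a lower number here means that less compound is tolerated, a higher number that more compound is tolerated), compound 3 (`Fc1ccc(NC(=S)Nc2cccc(C(F)(F)F)c2)cc1`) stands highest of the three numbers so far at 40000 nM against compound 2 (`CCCC[C@H]1CC[C@H](c2ccc(NC(=S)Nc3cccc(C(F)(F)F)c3)cc2)CC1`) at 17000 nM and compound 1 (`CC[C@H]1CC[C@H](c2ccc(NC(=S)Nc3cccc(C(F)(F)F)c3)cc2)CC1`) at 10000 nM in the same read-out. Compound 4 (`CCOC(=O)c1ccc(NC(=S)Nc2cccc(C(F)(F)F)c2)cc1`) carries ethoxycarbonyl in place of fluoro on an aromatic carbon, para to a large group. For the measured compounds named here, two measured steps touch this same place: a 4.0-fold higher number from compound 1 to compound 3 (0.60 log units; beyond the scatter) with fluoro in place of 4-ethylcyclohexyl, and a 2.4-fold higher number from compound 2 to compound 3 (0.37 log units; beyond the scatter) with fluoro in place of 4-butylcyclohexyl. The chain change between the two cyclohexyl compounds gave only a 1.7-fold higher number from compound 1 to compound 2 (0.23 log units; within the scatter) and offers little guidance. Only these two groups have been compared with fluoro, and no ester has been measured, so the direction is a weak guide. Going by a 2.4-fold higher number from compound 2 to compound 3 (0.37 log units; beyond the scatter) as the smaller of the two steps, a modest drop to a lower number is expected, possibly none beyond the scatter. The estimated step is a 1.6-fold lower number from compound 3 to compound 4 (0.20 log units; within the scatter) on this reading. In this assay the estimate for compound 4 is 25000 nM with values between 10000 nM and 55000 nM as its expected range.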

Compound 4, half-maximal cytotoxic concentration: 71000 nM
Beside the measured number, compound 4's estimate is 2.8-fold (0.45 log units) below it, outside the stated range (above it).
By their numbers in this assay, from the lowest: compounds 1 and 2 (each within the scatter of the next); then compounds 3 and 4 (each within the scatter of the next).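

In this assay the step of ethoxycarbonyl in place of fluoro on this aromatic carbon is a 1.8-fold higher number from compound 3 to compound 4 (0.25 log units; within the scatter) and so leaves the two groups unseparated, although ethoxycarbonyl brings more heavy atoms and hydrogen-bond acceptors that fluoro lacks. Against the cyclohexyl compounds the same replacement gives a 4.2-fold higher number from compound 2 to compound 4 (0.62 log units; beyond the scatter) and a 7.1-fold higher number from compound 1 to compound 4 (0.85 log units; beyond the scatter) so the separation earlier seen only for fluoro now also holds for a second, quite different group at this position. Nothing among the data speaks to what lies behind these numbers.

Going by these compounds, whether a carboxylic acid, a primary amide or a nitrile at this aromatic carbon would stay level with fluoro and ethoxycarbonyl remains open. So does the behaviour of a plain cyclohexyl ring or a short chain such as methyl, which would show how far the lower numbers belong to the 4-alkylcyclohexyl groups.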